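The source may hold more compounds than are shown below. What is called first, only, known or untested is meant among the compounds shown, and "the series" means these compounds.

Measured compounds in a functional assay on HepG2 cells (Homo sapiens) for cytotoxicity, read by MTT assay, with a stated time of 48 h; on this read-out higher numbers stand for weaker inhibition and lower numbers for stronger inhibition:
compound 1 `CCCCCCOc1ccc2c(Cl)ccnc2c1` gives 2420 nM
compound 2 `CCCCCCOc1ccc2c(NCCN(C)C)ccnc2c1` gives 1370 nM
compound 3 `CCCCCCCCOc1ccc2c(Cl)ccnc2c1` gives 2640 nM

Compound 2 sits at the low end of the three numbers, but its gaps to the others are small: a 1.8-fold lower number from compound 1 to compound 2 (0.25 log units; within the scatter), and compound 3 stands only a little further off, both within the scatter. Compound 4 `C=CCOc1ccc2c(NCCN(C)C)ccnc2c1` is derived from compound 2 by vinyl in place of pentyl on a saturated chain carbon bound to an oxygen on an aromatic ring. Among the measured compounds shown here, the one measured step that touches the chain, a 1.1-fold higher number from compound 1 to compound 3 (0.04 log units; within the scatter), lengthened the hexyloxy chain and stayed within the scatter; here the chain is shortened instead, to allyloxy, and no measured pair covers that direction. On the numbers shown, no step beyond the scatter is expected in this assay, with a wide range kept for the untested direction. The expected step is a 1.2-fold higher number from compound 2 to compound 4 (0.09 log units; within the scatter), and compound 4 is estimated at 1700 nM, between 800 nM and 3600 nM.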

Compound 4, half-maximal inhibitory concentration: 1660 nM
Compound 4: the middle estimate sits 1.0-fold (0.01 log units) above what was measured; low and high end bracket the measured number.
By their numbers in this assay, from the lowest: compounds 2, 4, 1 and 3 (each within the scatter of the next).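

In this assay, allyloxy in place of hexyloxy, with the (2-(dimethylamino)ethyl)amino group kept, gives a 1.2-fold higher number from compound 2 to compound 4 (0.08 log units; within the scatter). A shorter chain carrying a double bond therefore leaves the number within the scatter, as the longer chain did on the chloro compounds, a 1.1-fold higher number from compound 1 to compound 3 (0.04 log units; within the scatter). Nothing available accounts for this flat reading.

On these data alone, whether a chain with a terminal hydroxyl or a benzyl group on the oxygen would give a step beyond the scatter stays open. So does the reading of allyloxy with chloro in place of the amine.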